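Adding a Chloro Group at a Different Ring Position

The compounds below may be only part of what the source reports. "The series", "measured", "known", "first", "only" and "open" are said of these compounds alone.

Compound 2 `CC1(C)N=C(N)N=C(N)N1c1ccc(OCc2ccccc2S(=O)(=O)F)c(Cl)c1` gives 7.43 in an assay on isolated protein for inhibition of Dihydrofolate reductase (Mus musculus); a higher number here means a more potent compound, by a factor of ten per unit of this negative logarithm, a lower number a less potent compound. Among the measured compounds shown here, only two values exist so far, and compound 1 `CC1(C)N=C(N)N=C(N)N1c1ccc(OCc2c(Cl)cccc2S(=O)(=O)F)c(Cl)c1`, which in this assay gives 7.72, lies within the scatter of compound 2, so neither stands apart from the other. Compound 3 `CC1(C)N=C(N)N=C(N)N1c1ccc(OCc2ccc(Cl)cc2S(=O)(=O)F)c(Cl)c1` differs from compound 2 by chloro in place of hydrogen on an aromatic carbon. For the measured compounds named here, the one measured step that bears on this, a number 0.29 log units lower from compound 1 to compound 2 (within the scatter), was small and involved the reverse change, hydrogen in place of chloro, at another carbon of the same ring. Bringing a chloro group back, now meta to a fluorosulfonyl group, is therefore expected to shift the value only a little, if at all. For compound 3 the estimate in this assay is 7.6, within 7 to 8.1, which means an expected step of a number 0.17 log units higher from compound 2 to compound 3 (within the scatter) that should stay inside the scatter.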

Compound 3, logarithm of the reciprocal of the active concentration, log(1/C): 7.52
Estimate against measurement, compound 3: 0.08 log units above; the measured number falls inside the stated range.
By their numbers in this assay, from the lowest: compounds 2, 3 and 1 (each within the scatter of the next).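

Chloro in place of hydrogen at this carbon, meta to a fluorosulfonyl group and para to a large group, makes little difference in this assay (the step is a number 0.09 log units higher from compound 2 to compound 3 (within the scatter)). Together with the earlier step on another carbon of the same ring (a number 0.29 log units lower from compound 1 to compound 2 (within the scatter)), this shows that compound 2 stays within the scatter of its chloro partner at both of these carbons, so neither position yet stands out as sensitive to this change.

The compounds shown carry only hydrogen or chloro at these carbons, so it remains open whether a different group there, such as an amine, a carboxylic acid or a longer chain, would move the number beyond the scatter. Nothing available here gives a reason for the small size of these steps.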